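This account rests on a few compounds, and the source may have more. Where it says the series, first, only, none or still open, it means among the compounds named here.

Measured in a functional assay on K562 cells (Homo sapiens) for cytotoxicity, read by MTT assay, with a stated time of 24 h; on this read-out lower numbers stand for stronger inhibition and higher numbers for weaker inhibition:
- compound 1 `COc1cc(/C=C2\CN(C)C/C(=C\c3ccc(C#N)cc3)C2=O)cc(OC)c1`: 4650 nM
- compound 2 `COc1cc(/C=C2\CN(C)C/C(=C\c3ccc(Cl)cc3Cl)C2=O)cc(OC)c1OC`: > 20000 nM

Compound 2 has no numerical value in this assay. Its entry of > 20000 nM is a limit of the assay, so its position in the series is only bounded and not fixed.

Compound 3 `COc1cc(/C=C2\CN(C)C/C(=C\c3ccc(C#N)cc3)C2=O)cc(OC)c1OC` has not yet been measured. The structural change is 4-cyanophenyl in place of 2,4-dichlorophenyl on a double-bonded chain carbon bound to a double-bonded ring carbon. In words, it is 4-cyanophenyl in place of 2,4-dichlorophenyl on a double-bonded chain carbon bound to a double-bonded ring carbon.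

Going by the values given here, no measured pair isolates this change, so the only guide is a compound that shares the entering group. Compound 1 also carries 4-cyanophenyl and gives 4650 nM, which points to a move towards stronger inhibition for compound 3. The size of that move is uncertain, and a second reading at the limit remains possible.

The expected change is an at least 2.8-fold lower number from compound 2 to compound 3 (0.45 log units; beyond the scatter), in the direction of lower numbers.

Compound 3 is estimated at 7000 nM, with an expected range of 2500 nM to 20000 nM.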

Compound 3, half-maximal inhibitory concentration: 4290 nM
Beside the measured number, compound 3's estimate is 1.6-fold (0.21 log units) above it, and the stated range covers the measured number.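

In this assay, going by these compounds alone, 4-cyanophenyl in place of 2,4-dichlorophenyl on a double-bonded chain carbon bound to a double-bonded ring carbon gives an at least 4.6-fold lower number from compound 2 to compound 3 (0.66 log units; beyond the scatter), the first direct evidence that the group at this place changes the read-out with the rest of the structure held constant. Only the lower bound of this step is known, since compound 2 stands at a limit rather than a number: the limit of > 20000 nM in this assay, at which 1 of the 3 values shown sits. The second step, methoxy in place of hydrogen on an aromatic carbon, gives a 1.1-fold lower number from compound 1 to compound 3 (0.03 log units; within the scatter), which lies within the scatter, so with 4-cyanophenyl present this methoxy makes no readable difference.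

The compounds shown cannot separate the gain from the entering nitrile from the loss of the two chlorine atoms, and a 4-chlorophenyl, a plain phenyl or a 4-carboxyphenyl group at this place would help to tell these apart. Also open, as far as these compounds go, is whether the methoxy step would stay within the scatter with 2,4-dichlorophenyl in place of 4-cyanophenyl, since both compounds of that step carry the nitrile.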